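The source may report more compounds than this note shows. Statements on the series, on what has been measured and on what is new or still open speak of the compounds shown alone.

Compound 1 `Cc1cccc(-c2ccc(CCC(=O)N3CCCC3)cc2)c1` is a short amide whose aromatic end carries a methyl-bearing phenyl ring. Among the compounds with values here, in an assay on HEK293 cells for inhibition of N-acylethanolamine-hydrolyzing acid amidase (Rattus norvegicus), read by LC-MS, with a stated time of 30 min (a lower number here means a stronger inhibitor, a higher number a weaker inhibitor), compound 1 gives 16500 nM, and this is the only plain number obtained so far. Compound 2 `O=C(O)c1cccc(CCCCCCC(=O)N2CCCC2)c1` is a related amide with a longer chain and a carboxylic acid. In this assay compound 2 gives > 100000 nM, which is a limit of the assay rather than a number. Within the data shown here, compound 1 therefore stands alone as the one measured value, the other result sitting at the limit of > 100000 nM in this assay, at which 1 of the 2 values shown sits. Compound 3 `O=C(CCc1ccc(-c2ccsc2)cc1)N1CCCC1` is the compound still to be tested; it differs from compound 1 by thiophen-3-yl in place of 3-methylphenyl on an aromatic carbon, a change made on an aromatic carbon of the shared core. Among the measured compounds shown here, no measured pair shows a comparable swap, so the size of the step in this assay cannot be read from the data, and a modest loss or no change beyond the scatter is expected. Compound 3 is estimated at 25000 nM, between 8000 nM and 80000 nM, which would mean an expected step of a 1.5-fold higher number from compound 1 to compound 3 (0.18 log units; within the scatter).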

Compound 3, half-maximal inhibitory concentration: 2500 nM
The estimate for compound 3 lay 10-fold (1.00 log units) above the measured number; the whole stated range lies above it.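

At this aromatic carbon of the shared core, thiophen-3-yl in place of 3-methylphenyl gives in this assay a 6.6-fold lower number from compound 1 to compound 3 (0.82 log units; beyond the scatter), so the ring carried at this position clearly affects the result. Within the data shown here, a five-membered aromatic ring with one sulfur atom is therefore not only accepted here but gives the stronger inhibitor of this pair, and this is the first step between compounds differing in one place that can be read. Nothing measured here explains the direction or size of this step.

The swap changes two things at once, removing the methyl and replacing the six-membered ring, and a plain phenyl at this position would be needed to separate them. On these data alone, it also remains open how other rings, such as thiophen-2-yl or a pyridine ring, would compare on this carbon.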